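Chain Length and a Ring Swap in a Piperazine Series

A few compounds are considered here, and "the series" means these few. Any claim that something is new, unique, unknown or untested is made for them only; others in the source may bear on it.

Measured compounds:
Compound 1 `c1ccc2c(c1)CC(CCN1CCN(c3cccc4c3OCCO4)CC1)C2`: 0.66 mg/kg
Compound 2 `c1ccc2c(c1)CC(CCCN1CCN(c3cccc4c3OCCO4)CC1)C2`: 1.73 mg/kg
Compound 3 `Clc1cccc2c1CC2CCN1CCN(c2cccc3c2OCCO3)CC1`: 20 mg/kg

All three were tested in an assay for activation of Adrenergic receptor alpha-1 (Rattus norvegicus); on this read-out higher numbers stand for an effect only at larger amounts of compound and lower numbers for an effect already at smaller amounts. Compound 1 gives 0.66 mg/kg, compound 2 gives 1.73 mg/kg and compound 3 gives 20 mg/kg. The difference between the cores of compound 1 and compound 2 is not broken down here. Compound 3 differs from compound 1 by a group of 9 heavy atoms (8 carbon, 1 chlorine; one four-membered non-aromatic ring of carbon only, one six-membered aromatic ring of carbon only) in place of a group of 9 heavy atoms (9 carbon; one five-membered non-aromatic ring of carbon only, one six-membered aromatic ring of carbon only), on a saturated chain carbon, two bonds along the chain from an amine nitrogen in a ring, and this change brought a 30-fold higher number from compound 1 to compound 3 (1.48 log units; beyond the scatter).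

Compound 4 `Clc1cccc2c1CC2CCCN1CCN(c2cccc3c2OCCO3)CC1` has not yet been measured in this assay. It differs from compound 2 by a group of 9 heavy atoms (8 carbon, 1 chlorine; one four-membered non-aromatic ring of carbon only, one six-membered aromatic ring of carbon only) in place of a group of 9 heavy atoms (9 carbon; one five-membered non-aromatic ring of carbon only, one six-membered aromatic ring of carbon only), on a saturated chain carbon, three bonds along the chain from an amine nitrogen in a ring. This is the same kind of change as from compound 1 to compound 3, but the place is not identical: in compound 3 the new group sits two bonds along the chain from the amine nitrogen, in compound 4 three bonds along. If the change acts alike on the longer chain, the step expected from compound 2 to compound 4 would be a 23-fold higher number from compound 2 to compound 4 (1.36 log units; beyond the scatter), resting on the single measured step of a 30-fold higher number from compound 1 to compound 3 (1.48 log units; beyond the scatter). Compound 4 is therefore estimated at 40 mg/kg, with a range from 10 mg/kg to 150 mg/kg.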

Compound 4, dose for half-maximal effect: 1.25 mg/kg
Compound 4: the middle estimate sits 32-fold (1.51 log units) above what was measured; the whole stated range lies above it.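

In this assay, placing the group with the chlorine and the four-membered ring where 2,3-dihydro-1H-inden-2-yl stood, three bonds along the chain from an amine nitrogen in a ring, gave a 1.4-fold lower number from compound 2 to compound 4 (0.14 log units; within the scatter), so the same change did not act alike on the two cores: the same change on two cores in this assay, a 30-fold higher number (1.48 log units; beyond the scatter) from compound 1 to compound 3 and a 1.4-fold lower number (0.14 log units; within the scatter) from compound 2 to compound 4, 42-fold (1.62 log units) apart, beyond the scatter of two such steps. A step measured on the core of compound 1 was therefore a poor guide to the same change on the core of compound 2, and the large shift seen on the first core did not appear on the second. These two pairs do not show what lies behind the difference, and they give no general rule for other cores or other groups in this series.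

The compounds shown leave open how the change behaves on a still longer chain. They also leave open how much the chlorine and the four-membered ring each contribute, which the same ring carrying no chlorine, or carrying a fluorine or a methoxy group instead, could help to separate.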